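Swapping Fluoro for Chloro on the Benzyl Group

The compounds below may be only part of what the source reports. "The series", "measured", "known", "first", "only" and "open" are said of these compounds alone.

Measured so far in an ADME assay on NIH3T3 cells (Mus musculus) for cytotoxicity, with a stated time of 72 h (a higher number here means a weaker inhibitor, a lower number a stronger inhibitor), on the compounds below
- compound 1 `OC[C@H]1O[C@@H](n2cnc3c(NCc4cccc(F)c4)ncnc32)[C@H](O)[C@@H]1O` gives 84000 nM
- compound 2 `OC[C@H]1O[C@@H](n2cnc3c(NCc4ccc(F)cc4)ncnc32)[C@H](O)[C@@H]1O` gives 44300 nM

Among the compounds with values here, compound 2 cannot be told apart from compound 1 here, since the only measured step is a 1.9-fold lower number from compound 1 to compound 2 (0.28 log units; within the scatter) and that step only shifts the fluoro group. Within the data shown here, the one change to compound 3 `OC[C@H]1O[C@@H](n2cnc3c(NCc4ccc(Cl)cc4)ncnc32)[C@H](O)[C@@H]1O` is chloro in place of fluoro on an aromatic carbon, counted as chloro in place of fluoro on an aromatic carbon and leaving the shared core untouched. Among the measured compounds shown here, no measured step swaps these two groups, so no step beyond the scatter is expected in this assay for compound 3. Compound 3 is estimated at 40000 nM with an expected range from 18000 nM to 85000 nM in this estimate. The expected change is a 1.1-fold lower number from compound 2 to compound 3 (0.04 log units; within the scatter) and remains an estimate until measured.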

Compound 3, half-maximal inhibitory concentration: > 166000 nM
Compound 3 gave a limit, no number; the forecaster's own chance of this, stated with the estimate: 10%; middle value at least 4.1-fold (0.61 log units) away from the limit.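

In this assay, chloro in place of fluoro on an aromatic carbon gives an at least 3.7-fold higher number from compound 2 to compound 3 (0.57 log units; beyond the scatter), so this position responds to which halogen it carries, while moving the fluoro group gave no step beyond the scatter. Compound 3 gives a limit of the assay, not a number: the limit of > 166000 nM in this assay, at which 1 of the 3 values shown sits. The other comparison reads an at least 1.9-fold higher number from compound 1 to compound 3 (0.29 log units; that floor lies within the scatter), so that floor does not separate the two compounds.

From the compounds shown here alone, the true value of compound 3 remains open. So does how bromo, methyl or an amine would read at this place.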